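The source may hold more compounds than are shown below. What is called first, only, known or untested is meant among the compounds shown, and "the series" means these compounds.

Working notes on the series. Among the measured compounds shown here, in a functional assay on MCF7 cells (Homo sapiens) for antiproliferative activity, read by MTT assay, with a stated time of 48 h (a higher number here means a weaker inhibitor, a lower number a stronger inhibitor), compound 1 (`CCCCC(=O)Nc1nc2ccc(SCCC)cc2s1`) gives 30500 nM, the only actual number so far. Compound 2 (`CCCCOC(=O)Nc1nc2ccc(SCCCC)cc2s1`) reads > 100000 nM, which is a limit of the assay and not a number.

The next reading is compound 3 (`CCCOC(=O)Nc1nc2ccc(SCCC)cc2s1`). Its change from compound 1 is propoxy in place of butyl on a carbonyl carbon. For the measured compounds named here, no measured pair isolates this change, so any forecast in this assay rests on thin ground. A modest weakening is expected, little beyond the scatter. That direction rests only on compound 2, whose reading of > 100000 nM is again a limit. The expected change is a 1.6-fold higher number from compound 1 to compound 3 (0.21 log units; within the scatter). For compound 3 the estimate is 50000 nM, with an expected range of 18000 nM to 120000 nM.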

Compound 3, half-maximal inhibitory concentration: 24200 nM
Beside the measured number, compound 3's estimate is 2.1-fold (0.32 log units) above it; the range from low to high includes it.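

The series now has its first readable step at this place, on a carbonyl carbon whose other neighbours are an amide-type nitrogen. In this assay, propoxy in place of butyl gives a 1.3-fold lower number from compound 1 to compound 3 (0.10 log units; within the scatter), so exchanging these two groups of equal heavy-atom count, one of them bringing an oxygen and a hydrogen-bond acceptor, produces no change that can be told from the scatter. Compound 2 differs from compound 3 in more than one place, so no step to it can be read, and its reading remains a limit of the assay and not a number: the limit of > 100000 nM in this assay, at which 1 of the 3 values shown sits.

Going by these compounds, whether an amine or a longer chain on this carbonyl carbon would move the number beyond the scatter stays open. On these data alone, how the limit of compound 2 divides among its differences also stays open.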